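A few compounds are considered here, and "the series" means these few. Any claim that something is new, unique, unknown or untested is made for them only; others in the source may bear on it.

Measured in a functional assay on MT2 cells (Homo sapiens) for cytotoxicity, read by MTT assay; a higher number here means that more compound is tolerated, a lower number that less compound is tolerated:

- Compound 1 `CC(C)=CCOc1cccc(Nc2nccs2)c1`: 23000 nM
- Compound 2 `CC(C)=CCOc1cc(Nc2nccs2)ccc1C`: 17000 nM
- Compound 3 `CC(C)=CCOc1cc(Nc2nccs2)ccc1Cl`: 26000 nM

Compound 3 stands within the scatter of both other compounds, with a 1.1-fold higher number from compound 1 to compound 3 (0.05 log units; within the scatter) and a 1.5-fold higher number from compound 2 to compound 3 (0.18 log units; within the scatter). Compound 4 `CCCc1ccc(Nc2nccs2)cc1OCC=C(C)C` has not yet been measured. The change leading to it from compound 3 is propyl in place of chloro on an aromatic carbon.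

Among the measured compounds shown here, no measured step involves a propyl, so the evidence is indirect. Three steps exchange a group on an aromatic carbon. Methyl in place of hydrogen gave a 1.4-fold lower number from compound 1 to compound 2 (0.13 log units; within the scatter), chloro in place of hydrogen gave a 1.1-fold higher number from compound 1 to compound 3 (0.05 log units; within the scatter), and chloro in place of methyl gave a 1.5-fold higher number from compound 2 to compound 3 (0.18 log units; within the scatter). As far as these compounds go, all three stayed within the scatter, so no step beyond the scatter is expected in this assay, though a propyl remains untested. The expected step is a 1.4-fold lower number from compound 3 to compound 4 (0.14 log units; within the scatter). Compound 4 is estimated at 19000 nM, with an expected range from 9000 nM to 38000 nM.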

Compound 4, half-maximal cytotoxic concentration: 23000 nM
Estimate against measurement, compound 4: 1.2-fold (0.08 log units) below, within the range that was stated.
By their numbers in this assay, from the lowest: compounds 2, 1, 4 and 3 (each within the scatter of the next).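

At this position, para to the (1,3-thiazol-2-yl)amino group and ortho to the (3-methylbut-2-en-1-yl)oxy group, propyl in place of chloro stays within the scatter in this assay (a 1.1-fold lower number from compound 3 to compound 4 (0.05 log units; within the scatter)). The same holds against the compounds carrying methyl (a 1.4-fold higher number from compound 2 to compound 4 (0.13 log units; within the scatter)) and hydrogen (no change at the digits printed from compound 1 to compound 4 (within the scatter)), so a saturated chain now joins methyl and chloro among the groups here that produce no step beyond the scatter. No measurement on these compounds offers an explanation for this flat result.

As far as these compounds go, whether an amine, a carboxylic acid or a chain longer than propyl on this aromatic carbon would also stay within the scatter remains open. From the compounds shown here alone, how this assay would read a change to the (3-methylbut-2-en-1-yl)oxy group or the (1,3-thiazol-2-yl)amino group also remains open.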